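The compounds below may be only part of what the source reports. "The series", "measured", "known", "first", "only" and "open" are said of these compounds alone.

In a functional assay on CEM-DNR-bulk cells (Homo sapiens), read by MTT assay, with a stated time of 72 h (a higher number here means a weaker inhibitor, a lower number a stronger inhibitor), compound 1 `CNc1ncnc2c1c(-c1ccsc1)cn2[C@@H]1O[C@H](CO)[C@@H](O)[C@H]1O` gives > 20000 nM, a limit of the assay and not a number. Compound 2 `Cc1ncnc2c1c(-c1cccs1)cn2[C@@H]1O[C@H](CO)[C@@H](O)[C@H]1O` gives > 20000 nM, which is also a limit and not a number. Compound 2 therefore stands at the limit of > 20000 nM in this assay, at which 2 of the 2 values shown sit, and no exact potency can be read for it.

Compound 3 `Cc1ncnc2c1c(-c1ccsc1)cn2[C@@H]1O[C@H](CO)[C@@H](O)[C@H]1O` has the same atoms as compound 2, joined differently, with thiophen-3-yl in place of thiophen-2-yl on an aromatic carbon. Among the compounds with values here, no measured step between two compounds is available as a guide, so no change beyond the scatter is expected in this assay, in either direction. This expectation rests on compound 2 at its limit of > 20000 nM. The estimated change is a number no higher from compound 2 to compound 3 (the limit leaves the size open). Compound 3 is expected at 20000 nM, with an estimated range of 6000 nM to 40000 nM.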

Compound 3, half-maximal inhibitory concentration: 8560 nM
Compound 3: the middle estimate sits 2.3-fold (0.37 log units) above what was measured, and the stated range covers the measured number.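

With thiophen-3-yl in place of thiophen-2-yl on an aromatic carbon, this assay shows an at least 2.3-fold lower number from compound 2 to compound 3 (0.36 log units; beyond the scatter), so how the thiophene is joined matters at this place, even though the two groups have the same atoms. With methyl in place of methylamino and thiophen-3-yl kept, this assay shows an at least 2.3-fold lower number from compound 1 to compound 3 (0.36 log units; beyond the scatter), so the group on the other aromatic carbon matters as well. The full size of both steps stays open, since each starts from a limit of the assay and not a number: the limit of > 20000 nM in this assay, at which 2 of the 3 values shown sit.

Going by these compounds, whether phenyl or furan-3-yl at the thiophene's place would lower the number further remains open. So does whether an amine or a longer chain in place of methyl would do so.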